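A few compounds are considered here, and "the series" means these few. Any claim that something is new, unique, unknown or untested is made for them only; others in the source may bear on it.

Compound 1 `C#Cc1cn([C@@H]2O[C@H](CO)[C@@H](O)[C@H]2O)c2ncnc(OC)c12` gives 380 nM in a functional assay on K562 cells (Homo sapiens), read by MTT assay, with a stated time of 72 h; on this read-out lower numbers stand for stronger inhibition and higher numbers for weaker inhibition. It stands level with compound 2 `COc1ncnc2c1c(-c1ccco1)cn2[C@@H]1O[C@H](CO)[C@@H](O)[C@H]1O`, which gives 380 nM, the two together the lowest of the three numbers, and no change at the digits printed from compound 1 to compound 2 (within the scatter). Compound 3 `COc1ncnc2c1c(-c1cc3ccccc3o1)cn2[C@@H]1O[C@H](CO)[C@@H](O)[C@H]1O` gives 13100 nM, so that a 34-fold higher number from compound 1 to compound 3 (1.54 log units; beyond the scatter). Compound 4 `C#Cc1cn([C@@H]2O[C@H](CO)[C@@H](O)[C@H]2O)c2nc(N)nc(OC)c12` differs from compound 1 in one place: amino in place of hydrogen on an aromatic carbon. Among the compounds with values here, none of the measured steps touches this place; all three swap the ethynyl group, and even the large 34-fold higher number from compound 2 to compound 3 (1.54 log units; beyond the scatter) says nothing about an amino group entering here. The analyst therefore expects no step beyond the scatter, with no change at the digits printed from compound 1 to compound 4 (within the scatter). Compound 4 is estimated at 380 nM, within a range of 100 nM to 1500 nM.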

Compound 4, half-maximal inhibitory concentration: > 20000 nM
Compound 4 gave a limit, no number; the forecaster's own chance of this, stated with the estimate: 5%; middle value at least 52-fold (1.72 log units) from the limit.
By their numbers in this assay, from the lowest: compounds 1 and 2 (each within the scatter of the next); then compound 3. At a limit, above all of these: compound 4.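

In this assay, amino in place of hydrogen on the aromatic carbon between two ring nitrogen atoms brings an at least 52-fold higher number from compound 1 to compound 4 (1.72 log units; beyond the scatter). Within the data shown here, this shows that this position, which none of the earlier steps touched, is sensitive to change: a single added heavy atom here is enough for a large step. The result for compound 4 is a limit of the assay, not a number: the limit of > 20000 nM in this assay, at which 1 of the 4 values shown sits.

The compounds shown leave open whether the loss is specific to amino or would follow from other groups at this carbon, such as methyl, chlorine or methylamino. They also leave open whether amino would have the same effect with furan-2-yl in place of ethynyl.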